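Series notes: the 4-bromothiophen-2-yl analogue, compound 3

The compounds below may be only part of what the source reports. "The series", "measured", "known", "first", "only" and "open" are said of these compounds alone.

Values in an assay on CHO cells for displacement of a labelled ligand from adenosine receptor A1 (Homo sapiens) (on this read-out higher numbers stand for weaker inhibition and lower numbers for stronger inhibition), so far:
compound 1 `O=c1oc2c(O)cccc2cc1-c1cccs1` gives 3360 nM
compound 2 `O=c1oc2c(O)c(O)ccc2cc1-c1cccs1` gives 3230 nM

For the measured compounds named here, compound 2 and compound 1 lie within the scatter of each other in this assay: the single measured step, a 1.0-fold lower number from compound 1 to compound 2 (0.02 log units; within the scatter), is no more than noise. Compound 2 therefore stands at the same level as compound 1, and these two numbers are all that the series offers.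

Compound 3 `O=c1oc2c(O)c(O)ccc2cc1-c1cc(Br)cs1` is not yet measured. It differs from compound 2 by bromo in place of hydrogen on an aromatic carbon. Going by the values given here, no measured step bears directly on this change: the only step available concerns a hydroxy on the shared core and leaves the thiophene untouched. The series has so far been flat, and nothing here argues for a large move in either direction. A step of a 1.3-fold lower number from compound 2 to compound 3 (0.11 log units; within the scatter) is expected, which stays within the scatter, with a wide range to reflect the absence of any comparable step.

Compound 3 is estimated at 2500 nM in this assay, with a range from 700 nM to 9000 nM.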

Compound 3, inhibition constant: 16300 nM
Estimate against measurement, compound 3: 6.5-fold (0.81 log units) below; the measured number lies above the stated range.
By their numbers in this assay, from the lowest: compounds 2 and 1 (each within the scatter of the next); then compound 3.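

In this assay, for the compounds shown here, the thiophene is the first place where a change moves the number beyond the scatter: a 5.0-fold higher number from compound 2 to compound 3 (0.70 log units; beyond the scatter), whereas the hydroxy change on the shared core, a 1.0-fold lower number from compound 1 to compound 2 (0.02 log units; within the scatter), stays within it. Bromo on this aromatic carbon, two ring bonds from the ring sulfur and two ring bonds from the ring atom that bears a large group, therefore weakens inhibition, so thiophen-2-yl to 4-bromothiophen-2-yl is a modest step in the unfavourable direction, though it rests on one pair of compounds with the core of compound 2 in place. No available measurement bears on why this step occurs.

The compounds shown leave open whether the weakening is particular to bromo or would also appear with chloro, fluoro, methyl, an amine or a carboxylic acid on the same ring carbon. Also open, from the compounds shown here alone, is whether bromo at another carbon of the thiophene, or the same 4-bromothiophen-2-yl group on the core of compound 1, would give a step of similar size.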